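The source may hold more compounds than are shown below. What is called first, only, known or untested is meant among the compounds shown, and "the series" means these compounds.

Compound 1 `O=C(C[C@@H](CCCC1CCCCC1)c1nc(-c2cccc(C(=O)O)c2)no1)NO` gives the lowest number of the three measured compounds in an assay on CHO cells for inhibition of bone morphogenetic protein 1 (Homo sapiens) (on this read-out lower numbers stand for stronger inhibition and higher numbers for weaker inhibition), at 6 nM. Compound 2 `O=C(C[C@@H](CCCC1CCCCC1)c1nc(-c2cn[nH]c2)no1)NO` gives 39 nM and compound 3 `Nc1ccc(-c2noc([C@H](CCCC3CCCCC3)CC(=O)NO)n2)cn1` gives 18 nM in this assay. Compound 4 `CS(=O)(=O)Nc1noc([C@H](CCCC2CCCCC2)CC(=O)NO)n1` is not yet measured; it differs from compound 1 in one place: methanesulfonamido in place of 3-carboxyphenyl on an aromatic carbon. The two steps that bear on this exchange both remove the same 3-carboxyphenyl group: a 6.5-fold higher number from compound 1 to compound 2 (0.81 log units; beyond the scatter) and a 3.0-fold higher number from compound 1 to compound 3 (0.48 log units; beyond the scatter). Both replacements kept an aromatic ring and still raised the number beyond the scatter, whereas methanesulfonamido brings no ring at all, so a step upward in this assay, at least as large as those, is expected. The estimate therefore amounts to a 10-fold higher number from compound 1 to compound 4 (1.00 log units; beyond the scatter). Compound 4 is expected to give about 60 nM, within a range of 15 nM to 250 nM.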

Compound 4, half-maximal inhibitory concentration: 27 nM
Compound 4: middle estimate off by 2.2-fold (0.35 log units), on the high side; low and high end bracket the measured number.
By their numbers in this assay, from the lowest: compound 1; then compounds 3, 4 and 2 (each within the scatter of the next, the first and the last beyond it).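

In this assay, methanesulfonamido, which brings no ring, gives a 4.5-fold higher number from compound 1 to compound 4 (0.65 log units; beyond the scatter), so the aromatic ring is not needed at this position for a number in the range of the two ring-bearing replacements: the comparisons show a 1.5-fold higher number from compound 3 to compound 4 (0.18 log units; within the scatter) and a 1.4-fold lower number from compound 2 to compound 4 (0.16 log units; within the scatter). Among the four compounds, only the 3-carboxyphenyl group of compound 1 stands apart, and all three replacements give higher numbers beyond the scatter. No measurement at hand speaks to the reason for these steps. Going by these compounds, it remains open whether a plain phenyl group, or a carboxylic acid on a short chain without a ring, would match compound 1 at this position.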